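The source may report more compounds than this note shows. Statements on the series, on what has been measured and on what is new or still open speak of the compounds shown alone.

Values in a functional assay on CHO cells (Homo sapiens) for antiproliferative activity against CHO (Cricetulus griseus), read by sulforhodamine B assay, with a stated time of 48 h; a lower number here means a stronger inhibitor, a higher number a weaker inhibitor:

compound 1 `COc1cccc(NS(=O)(=O)c2ccc(N3CCNC3=O)cc2)c1` — 330 nM
compound 2 `Cc1cc(C)cc(NS(=O)(=O)c2ccc(N3CCNC3=O)cc2)c1` — 210 nM
compound 3 `Cc1cccc(NS(=O)(=O)c2ccc(N3CCNC3=O)cc2)c1` — 230 nM

Compound 3 holds the second highest of the three numbers; compound 2 is nearest, compound 1 furthest, and both gaps lie within the scatter (a 1.1-fold higher number from compound 2 to compound 3 (0.04 log units; within the scatter); a 1.4-fold lower number from compound 1 to compound 3 (0.16 log units; within the scatter)).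

Compound 4 `CCc1cccc(NS(=O)(=O)c2ccc(N3CCNC3=O)cc2)c1` differs from compound 3 by methyl in place of hydrogen on a saturated chain carbon bound to an aromatic carbon. Among the compounds with values here, the steps that bear on this are the earlier changes of the small substituent on the same aryl ring: a 1.4-fold lower number from compound 1 to compound 3 (0.16 log units; within the scatter) and a 1.1-fold higher number from compound 2 to compound 3 (0.04 log units; within the scatter), with a 1.6-fold lower number from compound 1 to compound 2 (0.20 log units; within the scatter) also small. None moved the number beyond the scatter, so no step beyond the scatter is expected in this assay for the exchange to ethyl either.

The expected step is no change at the digits printed from compound 3 to compound 4 (within the scatter). Compound 4 is therefore estimated at 230 nM, with a range from 120 nM to 450 nM.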

Compound 4, half-maximal inhibitory concentration: 230 nM
Beside the measured number, compound 4's estimate shows no gap at the digits printed; the range from low to high includes it.
By their numbers in this assay, from the lowest: compounds 2, 3, 4 and 1 (each within the scatter of the next).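

In this assay, the exchange of 3-methylphenyl for 3-ethylphenyl gives no change at the digits printed from compound 3 to compound 4 (within the scatter), so a methyl on this saturated chain carbon bound to an aromatic carbon leaves the number within the scatter. The other two aryl comparisons read a 1.1-fold higher number from compound 2 to compound 4 (0.04 log units; within the scatter) and a 1.4-fold lower number from compound 1 to compound 4 (0.16 log units; within the scatter), so ethyl joins methyl, methoxy and the 3,5-dimethylphenyl group as indistinguishable here. No evidence on the reason for this flat result is available.

Open, from the compounds shown here alone, is whether a longer chain, or an amine or carboxylic acid at the end of the chain, would still leave the number within the scatter.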